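Bromo to iodo in a halophenyl series

This account rests on a few compounds, and the source may have more. Where it says the series, first, only, none or still open, it means among the compounds named here.

In a functional assay on A-375 cells (Homo sapiens) for cytotoxicity, read by CCK-8 assay, with a stated time of 24 h (on this read-out higher numbers stand for weaker inhibition and lower numbers for stronger inhibition), the following values stand so far:
- compound 1 `COc1ccccc1Oc1c(N)nc(-c2cccc(F)c2)nc1OCCO` gives 8530 nM
- compound 2 `COc1ccccc1Oc1c(N)nc(-c2ccc(Cl)cc2)nc1OCCO` gives > 80000 nM (a limit of the assay, not a number)
- compound 3 `COc1ccccc1Oc1c(N)nc(-c2cccc(Br)c2)nc1OCCO` gives 650 nM

Compound 3 holds the lowest number of the set at 650 nM, and its steps from both other compounds lie beyond the scatter. The next structure is compound 4 `COc1ccccc1Oc1c(N)nc(-c2cccc(I)c2)nc1OCCO`, with the change (iodo in place of bromo on an aromatic carbon), that is, iodo in place of bromo on an aromatic carbon, meta to a large group.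

Among the measured compounds shown here, the nearest precedent is the halogen exchange at the same place, a 13-fold lower number from compound 1 to compound 3 (1.12 log units; beyond the scatter), a large step for bromo in place of fluoro. The step of an at least 120-fold lower number from compound 2 to compound 3 (2.09 log units; beyond the scatter) also moves the halogen and starts from a limit, so it bears less directly. A single halogen exchange gives thin support for a trend. A small further fall in this assay is therefore the lean, but no step beyond the scatter is expected. The expected step is a 1.4-fold lower number from compound 3 to compound 4 (0.16 log units; within the scatter). For compound 4 the estimated value is 450 nM, with an expected range of 120 nM to 2500 nM.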

Compound 4, half-maximal inhibitory concentration: 1230 nM
Beside the measured number, compound 4's estimate is 2.7-fold (0.44 log units) below it; the range from low to high includes it.
By their numbers in this assay, from the lowest: compounds 3 and 4 (each within the scatter of the next); then compound 1. At a limit, above all of these: compound 2.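

In this assay, iodo in place of bromo at this place opens no real gap, a 1.9-fold higher number from compound 3 to compound 4 (0.28 log units; within the scatter), so the two compounds cannot be ordered and the series shows no further gain from bromo to iodo. The gain over the fluoro compound holds with iodo as well, a 6.9-fold lower number from compound 1 to compound 4 (0.84 log units; beyond the scatter), so the step seen with bromo is not confined to that one halogen. The step of an at least 65-fold lower number from compound 2 to compound 4 (1.81 log units; beyond the scatter) starts from a limit, not a number: the limit of > 80000 nM in this assay, at which 1 of the 4 values shown sits.

Open, as far as these compounds go, is whether 3-chlorophenyl would sit with the 3-bromophenyl and 3-iodophenyl compounds or with the 3-fluorophenyl compound, and whether 4-bromophenyl would keep the low numbers of its 3-bromophenyl isomer. Also open, from the compounds shown here alone, is whether a non-halogen group at this place, such as methyl or trifluoromethyl, would serve as well as bromo or iodo.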